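The source may hold more compounds than are shown below. What is called first, only, known or untested is meant among the compounds shown, and "the series" means these compounds.

Working notes on the series. In an ADME assay on L02 cells (Homo sapiens) for antiproliferative activity, read by MTT assay, with a stated time of 48 h (on this read-out higher numbers stand for weaker inhibition and lower numbers for stronger inhibition), compound 2 `CCOc1ccc(-n2nncc2CN2C(=O)C3(C(C#N)=C(N)Oc4c(N)cc5nc6ccccc6nc5c43)c3ccccc32)cc1` gives > 50000 nM, which is a limit of the assay and not a number. Compound 1 `Cc1ccccc1-n1nncc1CN1C(=O)C2(C(C#N)=C(N)Oc3c(N)cc4nc5ccccc5nc4c32)c2ccccc21` gives in this assay > 50000 nM, likewise a limit. For the measured compounds named here, the one measured step, a step that the two limits leave unreadable from compound 1 to compound 2, therefore cannot be sized; this reflects (the limit of > 50000 nM in this assay, at which 2 of the 2 values shown sit), and nothing in the numbers separates the two compounds.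

Compound 3 `N#CC1=C(N)Oc2c(N)cc3nc4ccccc4nc3c2C12C(=O)N(Cc1cnnn1-c1ccc([N+](=O)[O-])cc1)c1ccccc12` is not yet measured in this assay. It differs from compound 2 by nitro in place of ethoxy on an aromatic carbon. Going by the values given here, no measured step bears on this change: the step from compound 1 to compound 2, the only one in hand, is unreadable, and it concerns the same aromatic nitrogen substituent but a different pair of groups. With both measured values at the limit, the expectation for compound 3 can rest only on that: no step beyond the scatter is expected, and the most likely outcome is another limit. The expected step in this assay is a step that the limit leaves unreadable from compound 2 to compound 3. Compound 3 is estimated at 60000 nM, with a range from 20000 nM to 200000 nM, the figure standing for a value most likely again reported only as a limit.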

Compound 3, half-maximal inhibitory concentration: > 50000 nM
Compound 3 gave a limit, no number; the forecaster's own chance of this, stated with the estimate: 80%; the middle value does not contradict the limit.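

In this assay compound 3 gives > 50000 nM, a limit and not a number. No new step can be read among compound 1, compound 2 and compound 3: the limit of > 50000 nM in this assay, at which 3 of the 3 values shown sit. The compounds shown leave open how the 2-methylphenyl, 4-ethoxyphenyl and 4-nitrophenyl groups compare in this assay.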